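Methyl for Methoxy: What Compound 4 Should Show

A few compounds are considered here, and "the series" means these few. Any claim that something is new, unique, unknown or untested is made for them only; others in the source may bear on it.

Measured in a functional assay on HCT-116 cells (Homo sapiens) for inhibition, read by MTT assay, with a stated time of 48 h; on this read-out higher numbers stand for weaker inhibition and lower numbers for stronger inhibition:
compound 1 `COc1ccc(-n2c(SCc3ccc(C)cc3)nnc2-c2cc(OC)c(OC)c(OC)c2)cc1` gives 33300 nM;
compound 2 `COc1ccc(CSc2nnc(-c3cc(OC)c(OC)c(OC)c3)n2-c2ccc(OC)cc2)cc1` gives 49600 nM;
compound 3 `COc1ccc(CSc2nnc(-c3cc(OC)c(OC)c(OC)c3)n2-c2ccc(N(C)C)cc2)cc1` gives 1150 nM.

Compound 3 and compound 1 each differ from compound 2 in one place. The change dimethylamino in place of methoxy on an aromatic carbon brought a 43-fold lower number from compound 2 to compound 3 (1.63 log units; beyond the scatter). The change methyl in place of methoxy on an aromatic carbon brought a 1.5-fold lower number from compound 2 to compound 1 (0.17 log units; within the scatter).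

Compound 4 `COc1cc(-c2nnc(SCc3ccc(C)cc3)n2-c2ccc(N(C)C)cc2)cc(OC)c1OC` has not yet been measured in this assay. It differs from compound 3 by methyl in place of methoxy on an aromatic carbon, the same change as that made from compound 2 to compound 1, the place being described in identical words. The two cores on which this change sits differ by dimethylamino in place of methoxy on an aromatic carbon.

For compound 4 a step of a 1.4-fold lower number from compound 3 to compound 4 (0.13 log units; within the scatter) is expected, resting on a 1.5-fold lower number from compound 2 to compound 1 (0.17 log units; within the scatter), which lay within the scatter. Compound 4 is therefore estimated at 850 nM, between 300 nM and 2500 nM.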

Compound 4, half-maximal inhibitory concentration: > 60000 nM
Compound 4 was reported as a limit; the forecaster's own chance of this, stated with the estimate: 2%; at least 70-fold (1.84 log units) between middle value and limit.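

In this assay, methyl in place of methoxy brought an at least 52-fold higher number from compound 3 to compound 4 (1.71 log units; beyond the scatter), so this change did not carry over from the core of compound 2 to the core of compound 3: the same change on two cores in this assay, a 1.5-fold lower number (0.17 log units; within the scatter) from compound 2 to compound 1 and an at least 52-fold higher number (1.71 log units; beyond the scatter) from compound 3 to compound 4, at least 77-fold (1.89 log units) apart, beyond the scatter of two such steps. Seen from the other side, dimethylamino in place of methoxy brought an at least 1.8-fold higher number from compound 1 to compound 4 (0.25 log units; that floor lies within the scatter), so that change did not carry over between its two cores either: the same change on two cores in this assay, a 43-fold lower number (1.63 log units; beyond the scatter) from compound 2 to compound 3 and an at least 1.8-fold higher number (0.25 log units; that floor lies within the scatter) from compound 1 to compound 4, at least 77-fold (1.89 log units) apart, beyond the scatter of two such steps. Both steps rest on a limit and not on a number, so they show that the two changes do not simply add up, but not how large the true gap is or why it arises: the limit of > 60000 nM in this assay, at which 1 of the 4 values shown sits.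

The compounds shown leave open how far this dependence on the core extends. An ethyl group or a chlorine in place of the methyl of the 4-methylbenzyl group, or a primary amine in place of dimethylamino, might follow either compound 3 or compound 4.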